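Dropping the cyclohexylurea while keeping the carboxylic acid

The compounds below may be only part of what the source reports. "The series", "measured", "known", "first", "only" and "open" are said of these compounds alone.

compound 1 `CNC(=O)c1cnc(NC(=O)NC2CCCCC2)n2nc(-c3ccco3)nc12`: 8990 nM
compound 2 `O=C(Nc1ncc(C(=O)O)c2nc(-c3ccco3)nn12)NC1CCCCC1`, a limit only: > 100000 nM
compound 3 `CCOC(=O)c1cnc(NC2CC2)n2nc(-c3ccco3)nc12`: 60.7 nM

In an assay on CHO cells for displacement of a labelled ligand from adenosine receptor A1 (Homo sapiens) (a higher number here means a weaker inhibitor, a lower number a stronger inhibitor), compound 2 sits at the limit (the limit of > 100000 nM in this assay, at which 1 of the 3 values shown sits), so no number is known for it. Compound 4 `CCNc1ncc(C(=O)O)c2nc(-c3ccco3)nn12` differs from it by ethyl in place of cyclohexylcarbamoyl on a nitrogen on an aromatic ring. For the measured compounds named here, the one measured step, an at least 11-fold higher number from compound 1 to compound 2 (1.04 log units; beyond the scatter), concerns the carbonyl group and not this nitrogen, so no measured step bears directly on the change from compound 2 to compound 4. Compound 3 gives 60.7 nM, but it differs from compound 4 in two places, at the carbonyl and at the ring nitrogen, so it offers only a loose comparison. Since compound 4 keeps the carboxylic acid of compound 2, it is expected to remain weak, with an estimated 60000 nM between 10000 nM and 200000 nM, a step of an at least 1.6-fold lower number from compound 2 to compound 4 (0.22 log units; that floor lies within the scatter) expected but uncertain.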

Compound 4, inhibition constant: 11900 nM
For compound 4 the middle estimate is 5.0-fold (0.70 log units) above the measured one; the range from low to high includes it.
By their numbers in this assay, from the lowest: compound 3; then compounds 1 and 4 (each within the scatter of the next). At a limit, above all of these: compound 2.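

In this assay, ethyl in place of cyclohexylcarbamoyl on a nitrogen on an aromatic ring gives an at least 8.4-fold lower number from compound 2 to compound 4 (0.92 log units; beyond the scatter), so the group on this nitrogen changes the result even with the carboxylic acid kept. Compound 4, which keeps that acid, gives 11900 nM, so a measurable value is possible with the acid present. The value of compound 2 is a limit, so this step gives only a floor: the limit of > 100000 nM in this assay, at which 1 of the 4 values shown sits.

As far as these compounds go, what a longer chain such as butyl, or an unsubstituted amine, on this nitrogen would give with the acid kept remains open.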